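The compounds below may be only part of what the source reports. "The series", "measured", "known", "first", "only" and "open" are said of these compounds alone.

Measured in a functional assay on K562 cells (Homo sapiens) for antiproliferative activity, read by MTT assay; on this read-out higher numbers stand for weaker inhibition and lower numbers for stronger inhibition:
- compound 1 `O=C1NC(c2ccccc2)CN1S(=O)(=O)c1ccc2c(c1)CCCN2C(=O)C(F)(F)F`: > 20000 nM (a limit)
- compound 2 `NC(=O)N1CCCc2cc(S(=O)(=O)N3CC(c4ccccc4)NC3=O)ccc21`: 3660 nM
- compound 3 `CC1(c2ccccc2)CN(S(=O)(=O)c2ccc3c(c2)CCCN3C(=O)C(F)(F)F)C(=O)N1`: > 20000 nM (a limit)

Compound 3 has no number, only a limit, and stands at the limit of > 20000 nM in this assay, at which 2 of the 3 values shown sit.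

Compound 4 `CSc1ccc(NC(=O)N2CCCc3cc(S(=O)(=O)N4CC(C)(c5ccccc5)NC4=O)ccc32)cc1` differs from compound 3 by (4-(methylsulfanyl)phenyl)amino in place of trifluoromethyl on a carbonyl carbon. In words, this places (4-(methylsulfanyl)phenyl)amino in place of trifluoromethyl on a carbonyl carbon.

The closest measured step is an at least 5.4-fold lower number from compound 1 to compound 2 (0.73 log units; beyond the scatter). It replaces the same trifluoromethyl, there with amino, and its size is bounded only on one side. The other step, a step that the two limits leave unreadable from compound 1 to compound 3, gives no reading of the methyl that compound 3 and compound 4 share. For the measured compounds named here, no measured compound carries the (4-(methylsulfanyl)phenyl)amino group, so the size remains uncertain.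

A lower number is expected in this assay, on the strength of an at least 5.4-fold lower number from compound 1 to compound 2 (0.73 log units; beyond the scatter). The expected change is an at least 10-fold lower number from compound 3 to compound 4 (1.00 log units; beyond the scatter).

The estimate for compound 4 is 2000 nM, with an expected range of 300 nM to 12000 nM.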

Compound 4, half-maximal inhibitory concentration: > 20000 nM
Compound 4 was reported as a limit (the forecaster's own chance of this, stated with the estimate: 12%); at least 10-fold (1.00 log units) between middle value and limit.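

In this assay compound 4 gives > 20000 nM, a limit and not a number. Compound 3 also stands at a limit, and the step to compound 4 cannot be read. The compounds shown leave open what (4-(methylsulfanyl)phenyl)amino does on the core of compound 1, without the methyl.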